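The source may hold more compounds than are shown below. What is called first, only, known or untested is meant among the compounds shown, and "the series" means these compounds.

Compound 1 `O=C(CCCCCNc1c(Nc2ccccc2)c(=O)c1=O)NO` was tested in an ADME assay on cells (Hepatocyte, Homo sapiens) for pharmacokinetics, read by LC-MS, with a stated time of 90 min, tested at 1 uM; a lower number here means slower removal, a higher number faster removal of the compound. In this assay compound 1 returned only a limit, < 4.8 uL/min, not a measured number. Compound 2 `O=C(CCCCNc1c(Nc2ccccc2)c(=O)c1=O)NO` likewise gave a limit, < 5 uL/min. Compound 3 `Cc1ccccc1[C@H](C)Nc1c(NCCCCCC(=O)NO)c(=O)c1=O` also reached no more than a limit, < 5 uL/min. The single pairing that differs in one place, a step that the two limits leave unreadable from compound 1 to compound 2, has a limit at both ends and so yields no readable size. Compound 1 thus stands at the floor of what this assay reports, and all three values shown sit at such a floor, as the limit of < 4.8 uL/min in this assay, at which 1 of the 3 values shown sits, and the limit of < 5 uL/min in this assay, at which 2 of the 3 values shown sit, record.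

Compound 4 `COc1ccc(Nc2c(NCCCCCC(=O)NO)c(=O)c2=O)cc1` differs from compound 1 by methoxy in place of hydrogen on an aromatic carbon. Going by the values given here, no measured step in this assay bears on this change: the only step recorded is the unreadable one from compound 1 to compound 2, and it concerns the saturated chain rather than the aromatic ring. With every measured value at a limit, there is no direction to read out for compound 4. Compound 4 is therefore expected to show a step that the limit leaves unreadable from compound 1 to compound 4, within the scatter. The estimate for compound 4 is 4 uL/min, with a range from 2 uL/min to 10 uL/min, and this assay is expected most likely to report only a limit again.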

Compound 4, intrinsic clearance in a liver preparation (reported as CLH), per the amount of preparation that the assay uses in the Hepatocyte assay: < 4.7 uL/min
Compound 4 gave a limit, no number; the forecaster's own chance of this, stated with the estimate: 70%; the middle value lies beyond the limit too.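

Going by these compounds alone, in the Hepatocyte assay compound 1 and compound 4 both returned only limits, so no step between them can be read. In a physicochemical assay for solubility, read by HPLC, in phosphate buffer, with a stated time of 24 h, at pH 7.4, tested at 100 uM (on this read-out higher numbers stand for higher solubility and lower numbers for lower solubility), compound 1 gives 47000000 nM and compound 4 gives 3300000 nM, which is a 14-fold lower number from compound 1 to compound 4 (1.15 log units; beyond the scatter). The compounds shown leave open how quickly any of them is removed in the Hepatocyte assay, where every value is a limit.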